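Methyl added to the aromatic ring of compound 2

The source may hold more compounds than are shown below. What is called first, only, known or untested is meant among the compounds shown, and "the series" means these compounds.

Of the compounds shown here, two have so far been read in an assay on PBMC cells for antagonist activity at Toll-like receptor 8 (Homo sapiens), read by HTRF, with stated times of 30 min and 20 h; on this read-out lower numbers stand for stronger inhibition and higher numbers for weaker inhibition. Compound 1 `Cc1cc(-c2ccc(=O)n(C)c2)cc2cnc(N3CCN(C(C)C)CC3)nc12` gives 45 nM in this assay. Compound 2 `Cc1cc(-c2ccc(=O)n(C)c2)cc2cn(C3CCNCC3)nc12` gives 320 nM in this assay, the higher of the two numbers, and compound 1 lies beyond the scatter below it. The two structures differ in several places at once, so nothing about any single change can be read from that pair.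

Compound 3 `Cc1cc(-c2cc(C)c3nn(C4CCNCC4)cc3c2)cn(C)c1=O` is the next compound and remains unmeasured. It departs from compound 2 in one place only: methyl in place of hydrogen on an aromatic carbon. Among the compounds with values here, no measured pair differs in just this place, so the size of the step has to be estimated without a precedent. A single methyl on an aromatic carbon is a small change, and the expected step is a 1.1-fold lower number from compound 2 to compound 3 (0.03 log units; within the scatter), most likely nothing beyond the scatter, with the direction left open. Compound 3 is therefore expected to give 300 nM in this assay, within a range from 100 nM to 900 nM.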

Compound 3, half-maximal inhibitory concentration: 33 nM
Compound 3: middle estimate off by 9.1-fold (0.96 log units), on the high side; measured number outside the range, below it.
By their numbers in this assay, from the lowest: compounds 3 and 1 (each within the scatter of the next); then compound 2.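

In this assay, within the data shown here, this is the first step that can be read at a single place, and the position proves responsive: methyl in place of hydrogen on an aromatic carbon of the six-membered aromatic ring with 1 nitrogen gives a 9.7-fold lower number from compound 2 to compound 3 (0.99 log units; beyond the scatter). The entering group is 1 carbon, with no ring, no hydrogen-bond donors or acceptors and no net charge, so even the smallest carbon substituent at this place, ortho to a group of 1 heavy atom and two atoms from the ring nitrogen, moves the number beyond the scatter. No measurement bears on why the step is this large.

The compounds shown leave open whether the step belongs to methyl itself or to any substituent on this carbon, a question that ethyl, methoxy, fluorine, chlorine or an amine at the same place would address. They also leave open whether the same methyl gives a step of similar size on the core of compound 1, which carries the isopropyl-substituted piperazine group instead of the piperidine group of compound 3.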